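Aryl swap on the shared core: expected potency

The source may report more compounds than this note shows. Statements on the series, on what has been measured and on what is new or still open speak of the compounds shown alone.

compound 1 `CCCCCCCCCCCCCCCCCCNC(=O)[C@@H]1CSC(c2cccc(O)c2)N1` 6700 nM
compound 2 `CCCCCCCCCCCCCCCCCCNC(=O)[C@@H]1CSC(c2ccc(OCC)cc2)N1` > 20000 nM

In a functional assay on PC-3 cells (Homo sapiens) for antiproliferative activity, read by sulforhodamine B assay (a higher number here means a weaker inhibitor, a lower number a stronger inhibitor), compound 1 gives 6700 nM. Compound 2 sits at the limit of > 20000 nM in this assay, at which 1 of the 2 values shown sits; its reading of > 20000 nM is a limit, not a number. For the measured compounds named here, the one measured step, an at least 2.9-fold higher number from compound 1 to compound 2 (0.47 log units; beyond the scatter), changes the same position. Compound 3 `CCCCCCCCCCCCCCCCCCNC(=O)[C@@H]1CSC(c2c(OC)cc(OC)cc2OC)N1` differs from compound 2 by 2,4,6-trimethoxyphenyl in place of 4-ethoxyphenyl on a saturated ring carbon. With compound 2 at a limit, no step beyond the scatter can be read from it. Compound 3 is therefore expected to remain weak, estimated at 20000 nM (range 7000 nM to 60000 nM). This estimate means a step of a number no higher from compound 2 to compound 3 (the limit leaves the size open), most likely within the scatter.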

Compound 3, half-maximal inhibitory concentration: 10600 nM
Compound 3: the middle estimate sits 1.9-fold (0.28 log units) above what was measured, within the range that was stated.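

Compound 3 carries no hydroxyl on its aryl group, yet a 1.6-fold higher number from compound 1 to compound 3 (0.20 log units; within the scatter) in this assay, so at this position 2,4,6-trimethoxyphenyl and 3-hydroxyphenyl cannot be told apart. Against 4-ethoxyphenyl, the change gives an at least 1.8-fold lower number from compound 2 to compound 3 (0.27 log units; that floor lies within the scatter), so its true size stays unknown. The reading of compound 2 is a limit, not a number: the limit of > 20000 nM in this assay, at which 1 of the 3 values shown sits.

Going by these compounds, whether an aminophenyl or a carboxyphenyl group on this carbon would move the reading beyond the scatter remains open. So does whether any aryl group here gives a stronger inhibitor than compound 1.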